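Replacing naphthalen-1-yl with 4-methylphenyl in compound 1

A few compounds are considered here, and "the series" means these few. Any claim that something is new, unique, unknown or untested is made for them only; others in the source may bear on it.

For the measured compounds named here, in a functional assay on HL-60 cells (Homo sapiens) for inhibition, read by CCK-8 assay, with a stated time of 48 h, tested at 20 uM (on this read-out lower numbers stand for less inhibition of growth and higher numbers for more inhibition of growth at the one concentration tested), compound 1 `COc1ccc(S(=O)(=O)Oc2ccccc2/C=C(\C#N)C(=O)Nc2nnc(Cc3cccc4ccccc34)s2)cc1` gives 98% and stands highest of the two numbers so far, while compound 2 `N#C/C(=C\c1ccccc1OS(=O)(=O)c1ccc([N+](=O)[O-])cc1)C(=O)Nc1nnc(Cc2cccc3ccccc23)s1` gives 18% and stands lower. Compound 3 `COc1ccc(S(=O)(=O)Oc2ccccc2/C=C(\C#N)C(=O)Nc2nnc(Cc3ccc(C)cc3)s2)cc1` carries 4-methylphenyl in place of naphthalen-1-yl on a saturated chain carbon bound to an aromatic carbon. Going by the values given here, the one measured step (a number 80 percentage points lower from compound 1 to compound 2 (beyond the scatter)) is large and downward but lies elsewhere, so it shows only that a single change can move this series widely. With compound 1 at 98% little room remains upward. A moderate fall is therefore expected (a number 26 percentage points lower from compound 1 to compound 3 (beyond the scatter)). Compound 3 is estimated at 72% with an expected range from 35% to 98% on this read-out.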

Compound 3, percent growth inhibition at one concentration: 100%
Compound 3: the middle estimate sits 28 percentage points below what was measured, and the stated range ends below it.
By their numbers in this assay, from the lowest: compound 2; then compounds 1 and 3 (each within the scatter of the next).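

In this assay, 4-methylphenyl in place of naphthalen-1-yl on a saturated chain carbon bound to an aromatic carbon gives a number 2 percentage points higher from compound 1 to compound 3 (within the scatter). At this place, then, one six-membered aromatic ring serves as well as the two of naphthalen-1-yl, and this position tolerates the exchange, unlike the change behind a number 80 percentage points lower from compound 1 to compound 2 (beyond the scatter) elsewhere in the molecule. No evidence at hand explains this result.

With compound 1 at 98% and compound 3 at 100%, this single-concentration read-out does not separate the two. From the compounds shown here alone, whether an amine or a carboxylic acid at this place would keep the read-out remains open.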